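The compounds below may be only part of what the source reports. "The series", "measured", "known", "first", "only" and "open" are said of these compounds alone.

Measured so far in a functional assay on A549 cells (Homo sapiens) for antiproliferative activity, read by MTT assay, with a stated time of 48 h; a higher number here means a weaker inhibitor, a lower number a stronger inhibitor:

- compound 1, `C/C(=C\CC/C(C)=C/CC[C@@H]1[C@@]2(C)CCC(=O)C(C)(C)[C@H]2CC[C@@]1(C)O)CC/C=C(\C)C(=O)OCc1cn(-c2ccc(C(F)(F)F)cc2)nn1` — > 150000 nM, a limit only
- compound 2, `C/C(=C\CC/C(C)=C/CC[C@@H]1[C@@]2(C)CCC(=O)C(C)(C)[C@H]2CC[C@@]1(C)O)CC/C=C(\C)C(=O)OCc1cn(-c2ccc(C)cc2)nn1` — > 150000 nM, a limit only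
- compound 3, `C/C(=C\CC/C(C)=C/CC[C@@H]1[C@@]2(C)CCC(=O)C(C)(C)[C@H]2CC[C@@]1(C)O)CC/C=C(\C)C(=O)OCc1cn(-c2cccc(C(F)(F)F)c2)nn1` — > 150000 nM, a limit only

Compound 3 thus stands at a limit of this assay and not at a number; the two other values shown sit at the same limit, so no ranking among compounds 1, 2 and 3 can be read. The steps a step that the two limits leave unreadable from compound 1 to compound 2, a step that the two limits leave unreadable from compound 1 to compound 3 and a step that the two limits leave unreadable from compound 2 to compound 3 are all unreadable for the same reason, as summed up in the limit of > 150000 nM in this assay, at which 3 of the 3 values shown sit.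

Compound 4, `C/C(=C\CC/C(C)=C/CC[C@@H]1[C@@]2(C)CCC(=O)C(C)(C)[C@H]2CC[C@@]1(C)O)CC/C=C(\C)C(=O)OCc1cn(-c2cccc(C)c2)nn1`, is the next one to measure. Its change from compound 3 is methyl in place of trifluoromethyl on an aromatic carbon. The step that bears on it most closely is a step that the two limits leave unreadable from compound 1 to compound 2, the same exchange at the other position of the phenyl, and that step has no readable size; the remaining steps add nothing beyond the shared limit. No step beyond the scatter is therefore expected, and compound 4 is expected to stay at or near the limit, with a step that the limit leaves unreadable from compound 3 to compound 4 as the implied step. The estimate for compound 4 in this assay is 200000 nM, within 60000 nM to 800000 nM.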

Compound 4, half-maximal inhibitory concentration: > 150000 nM
Compound 4 was reported as a limit; the forecaster's own chance of this, stated with the estimate: 85%; the middle value lies beyond the limit too.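

Compound 4 gives > 150000 nM in this assay, which is a limit only. No step from compound 1, compound 2 or compound 3 to compound 4 can be read: the limit of > 150000 nM in this assay, at which 4 of the 4 values shown sit.

The compounds shown leave open whether the four differ at all in this assay.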